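Shortening the amide-bearing chain in the series

The compounds below may be only part of what the source reports. "The series", "measured", "known", "first", "only" and "open" are said of these compounds alone.

Of the compounds shown here, three of the shared core have been measured. Compound 1 `COc1cc(CCCN(C)C)ccc1-c1ccc(C(=O)NS(=O)(=O)c2ccc(NCCSc3ccccc3)c([N+](=O)[O-])c2)cc1` gives 1230 nM in an assay on isolated protein for binding affinity to Apoptosis regulator Bcl-2 (Homo sapiens), read by fluorescence polarization; on this read-out higher numbers stand for weaker inhibition and lower numbers for stronger inhibition; compound 2 `COc1cc(CCC(=O)N(C)C)ccc1-c1ccc(C(=O)NS(=O)(=O)c2ccc(NCCSc3ccccc3)c([N+](=O)[O-])c2)cc1` gives 400 nM in this assay; compound 3 `CC(C)(C)OC(=O)N1CCN(c2ccc(C(=O)NS(=O)(=O)c3ccc(NCCSc4ccccc4)c([N+](=O)[O-])c3)cc2)CC1` gives 2880 nM in this assay. Compound 2 therefore stands lowest of the three numbers: the step of a 3.1-fold lower number from compound 1 to compound 2 (0.49 log units; beyond the scatter) is beyond the scatter, and the gap to compound 3 is larger still.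

Compound 4 `COc1cc(C(=O)N(C)C)ccc1-c1ccc(C(=O)NS(=O)(=O)c2ccc(NCCSc3ccccc3)c([N+](=O)[O-])c2)cc1` is not yet measured. Its change from compound 2 is dimethylcarbamoyl in place of 2-(dimethylcarbamoyl)ethyl on an aromatic carbon, on an aromatic carbon of a six-membered aromatic ring of carbon only, meta to a methoxy group and para to a large group. Among the measured compounds shown here, the only measured step on this side of the core is a 3.1-fold lower number from compound 1 to compound 2 (0.49 log units; beyond the scatter), which exchanged the terminal group of the saturated chain while keeping its length; no measured step removes the chain itself, and compound 3 carries a different group altogether. The size of the step to compound 4 is thus not anchored by a measured analogue. With the amide retained but brought directly onto the ring, a step in this assay of about a 1.6-fold higher number from compound 2 to compound 4 (0.21 log units; within the scatter) toward a higher number is expected, and it may well fall within the scatter. Compound 4 is estimated at 650 nM, with a range from 220 nM to 2000 nM.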

Compound 4, inhibition constant: 1980 nM
Estimate against measurement, compound 4: 3.0-fold (0.48 log units) below, and the stated range covers the measured number.
By their numbers in this assay, from the lowest: compound 2; then compounds 1, 4 and 3 (each within the scatter of the next, the first and the last beyond it).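

In this assay, the length of the chain counts at this position as well as its terminal group: with the dimethylcarbamoyl retained, replacing 2-(dimethylcarbamoyl)ethyl on the aromatic carbon gives a 5.0-fold higher number from compound 2 to compound 4 (0.69 log units; beyond the scatter), whereas the earlier step changed only the end of a chain of unchanged length. The second new comparison, a 1.6-fold higher number from compound 1 to compound 4 (0.21 log units; within the scatter), stays within the scatter, so dimethylcarbamoyl directly on the ring and 3-(dimethylamino)propyl cannot be told apart in this assay, and among these compounds the lowest number belongs only to compound 2, which combines the chain with the amide. No evidence is available on what lies behind the change in number on removing the chain.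

Still open, as far as these compounds go, is how a longer chain ending in dimethylcarbamoyl would compare with 2-(dimethylcarbamoyl)ethyl, and so whether the length in compound 2 is the best one at this position or only better than direct attachment. Equally open, from the compounds shown here alone, is how a carboxylic acid or a primary amide at the end of the same chain would read, and whether a dimethylamino group placed directly on the ring would follow the amide series.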